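The source may hold more compounds than are shown below. What is called first, only, known or untested is meant among the compounds shown, and "the series" means these compounds.

Measured compounds:
- Compound 1, `COc1ccc(-c2cc(/C=C/C(=O)c3ccc(N)cc3)[nH]n2)cc1`, gives 100%.
- Compound 2, `COc1ccc(C(=O)/C=C/c2cc(-c3cc(OC)c(OC)c(OC)c3)n[nH]2)cc1OC`, gives 101%.
- Compound 3, `COc1ccc(-c2cc(/C=C/C(=O)c3ccc(N)cc3)[nH]n2)cc1OC`, gives 99%.

These three compounds were tested in a functional assay on SW-620 cells (Homo sapiens) for cytotoxicity, read by sulforhodamine B assay, with a stated time of 48 h, tested at 0.01 uM; a lower number here means a stronger effect, a higher number a weaker effect of the compound at the concentration tested. The readings of compound 1, compound 2 and compound 3 all sit within the scatter of each other, so no order among them can be drawn. Compound 1 and compound 3 differ in one place: methoxy in place of hydrogen on an aromatic carbon. That change made the step of a number 1 percentage points lower from compound 1 to compound 3 (within the scatter).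

The difference between the core of compound 2 and the core of compound 1 is not broken down here. Compound 4, `COc1cc(C(=O)/C=C/c2cc(-c3cc(OC)c(OC)c(OC)c3)n[nH]2)cc(OC)c1OC`, has not yet been measured. It differs from compound 2 in one place: methoxy in place of hydrogen on an aromatic carbon. Around the place, the description adds that the new group is meta to a methoxy group, which the change from compound 1 to compound 3 does not say, so this is the same kind of change, not the same.

Because a number 1 percentage points lower from compound 1 to compound 3 (within the scatter) was within the scatter, the step of a number 1 percentage points lower from compound 2 to compound 4 (within the scatter) is expected to be of similar size. Compound 4 is therefore estimated at 100%, between 91% and 108%.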

Compound 4, a percentage reported as activity, at one concentration (the size of the read-out at that concentration, not a potency): 96%
Beside the measured number, compound 4's estimate is 4 percentage points above it; measured number inside the range.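

In this assay, methoxy in place of hydrogen on an aromatic carbon of compound 2 gives a reading a number 5 percentage points lower from compound 2 to compound 4 (within the scatter). Set beside the earlier case, the change shows no difference between the two cores: the same change on two cores in this assay, a number 1 percentage points lower (within the scatter) from compound 1 to compound 3 and a number 5 percentage points lower (within the scatter) from compound 2 to compound 4, 4 percentage points apart, within the scatter of two such steps. For the compounds shown here, this shows only that two small steps agree at the single concentration tested; neither step stands out from the scatter, so it does not show how the change would carry over on a core where it moved the reading clearly, nor whether its surroundings matter, although in compound 4 the new group is both ortho and meta to a methoxy group.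

The compounds shown leave open whether a different group on that aromatic carbon, such as ethoxy, a fluorine atom or a carboxylic acid, would shift the reading in this assay. They also leave open how these compounds would read at a higher concentration, where a step between them might be easier to see.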